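Aryl Hydrazone Variation on a Shared Urea Core

The compounds below may be only part of what the source reports. "The series", "measured", "known", "first", "only" and "open" are said of these compounds alone.

Compound 1 `COc1ccc(/C=N/NC(=O)Nc2ccc(Oc3ccnc(-c4nncn4CCN(C)C)c3)c(F)c2)c(OC)c1` gives 1780 nM in a functional assay on HT-29 cells (Homo sapiens) for cytotoxicity, read by MTT assay, with a stated time of 72 h; on this read-out higher numbers stand for weaker inhibition and lower numbers for stronger inhibition. Compound 2 `COc1cc(/C=N/NC(=O)Nc2ccc(Oc3ccnc(-c4nncn4CCN(C)C)c3)c(F)c2)ccc1O` gives 120 nM in this assay.

Compound 2 holds the lower of the two measured values, set apart from compound 1 by a 15-fold lower number from compound 1 to compound 2 (1.17 log units; beyond the scatter). Compound 3 `CN(C)CCn1cnnc1-c1cc(Oc2ccc(NC(=O)N/N=C/c3cccc(O)c3)cc2F)ccn1` carries 3-hydroxyphenyl in place of 4-hydroxy-3-methoxyphenyl on a carbon with a double bond to nitrogen. Going by the values given here, only the step from compound 1 to compound 2 bears on this change, and it shows that the aryl group on the hydrazone carbon shifts the read-out strongly. Losing the methoxy is expected to cost some potency, so compound 3 is estimated at 300 nM, between 80 nM and 1500 nM, a change of a 2.5-fold higher number from compound 2 to compound 3 (0.40 log units; beyond the scatter) expected in this assay.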

Compound 3, half-maximal inhibitory concentration: 330 nM
Estimate against measurement, compound 3: 1.1-fold (0.04 log units) below, within the range that was stated.
By their numbers in this assay, from the lowest: compound 2; then compound 3; then compound 1.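

In this assay, 3-hydroxyphenyl on a carbon with a double bond to nitrogen gives a 2.8-fold higher number from compound 2 to compound 3 (0.44 log units; beyond the scatter), so compound 2 keeps its lead, though by a modest step. The same change gives a 5.4-fold lower number from compound 1 to compound 3 (0.73 log units; beyond the scatter), which places the 3-hydroxyphenyl group of compound 3 clearly ahead of the 2,4-dimethoxyphenyl group of compound 1, yet behind 4-hydroxy-3-methoxyphenyl. No available evidence accounts for these differences.

As far as these compounds go, how an amine or a carboxylic acid would compare with the hydroxyl on this aryl group remains open. So does the standing of 4-hydroxyphenyl against compound 2.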